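Replacing (methylamino)methyl with Fluoro on Compound 2

The source may hold more compounds than are shown below. What is called first, only, known or untested is meant among the compounds shown, and "the series" means these compounds.

In an ADME assay on Caco-2 cells (Homo sapiens) for permeability, in the apical to basolateral direction (on this read-out lower numbers stand for lower permeability and higher numbers for higher permeability), compound 1 `Cn1nc2c(=O)n(CC3(O)CCN(Cc4ccc(-c5ccco5)cc4Cl)CC3)cnc2c1-c1ccc(CNC=O)cc1` gives 0.65 10^-6 cm/s and compound 2 `CNCc1ccc(-c2c3ncn(CC4(O)CCN(Cc5ccc(-c6ccco6)cc5Cl)CC4)c(=O)c3nn2C)cc1` gives 1.06 10^-6 cm/s, so compound 2 stands level with compound 1 within the scatter. Compound 3 `Cn1nc2c(=O)n(CC3(O)CCN(Cc4ccc(-c5ccco5)cc4Cl)CC3)cnc2c1-c1ccc(F)cc1` brings a new change, fluoro in place of (methylamino)methyl on an aromatic carbon. Within the data shown here, the only measured step, a 1.6-fold higher number from compound 1 to compound 2 (0.21 log units; within the scatter), swapped methyl for formyl on an amine nitrogen and stayed within the scatter. It is a weak guide, since the new change removes the whole group, so a modest rise beyond the scatter is expected, an estimated 2.8-fold higher number from compound 2 to compound 3 (0.45 log units; beyond the scatter). For compound 3 the estimate is 3 10^-6 cm/s, with an expected range of 1 10^-6 cm/s to 9 10^-6 cm/s.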

Compound 3, apparent permeability: 6.84 10^-6 cm/s
Estimate against measurement, compound 3: 2.3-fold (0.36 log units) below, within the range that was stated.
By their numbers in this assay, from the lowest: compounds 1 and 2 (each within the scatter of the next); then compound 3.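

At this aromatic carbon, this assay could not separate compound 1 from compound 2, whose side chains differ only on the nitrogen, yet fluoro in place of the whole chain gives a 6.5-fold higher number from compound 2 to compound 3 (0.81 log units; beyond the scatter) and an 11-fold higher number from compound 1 to compound 3 (1.02 log units; beyond the scatter) in the same read-out. So the number moves clearly once the nitrogen-bearing chain is gone, not when that nitrogen is merely altered. Nothing available explains this rise. Going by these compounds, whether fluoro itself matters stays open: a plain hydrogen, chloro or methoxy group here could separate losing the chain from adding fluorine.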